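The source may report more compounds than this note shows. Statements on the series, on what has been measured and on what is new or still open speak of the compounds shown alone.

Measured compounds:
compound 1, `C[C@@H](CF)OC(=O)N1CCC(O[C@H]2CC[C@H](Oc3cnc(S(C)(=O)=O)cn3)CC2)CC1`, 105%
compound 2, `CS(=O)(=O)c1cnc(O[C@H]2CC[C@H](OC3CCN(C(=O)C4(C(F)(F)F)CCCC4)CC3)CC2)cn1`, 95%
compound 3, `CS(=O)(=O)c1cnc(O[C@H]2CC[C@H](OC3CCN(C(=O)C4(C(F)(F)F)CC4)CC3)CC2)cn1`, 107%

All three share one core and differ only in the group on a carbonyl carbon. In a functional assay on isolated protein for agonist activity at Glucose-dependent insulinotropic receptor (Homo sapiens), read by HTRF and cAMP accumulation (on this read-out lower numbers stand for smaller maximal responses and higher numbers for larger maximal responses), compound 3 gives 107%, and compound 1 sits within the usual scatter of it; compound 2 alone lies beyond, as a number 12 percentage points higher from compound 2 to compound 3 (beyond the scatter) shows. The other steps, a number 10 percentage points lower from compound 1 to compound 2 (within the scatter) and a number 2 percentage points higher from compound 1 to compound 3 (within the scatter), both stay within the scatter, so exchanging one group for another on the carbonyl carbon has left the maximal response essentially at the level of the reference.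

Compound 4, `CS(=O)(=O)c1cnc(O[C@H]2CC[C@H](OC3CCN(CC4(C(F)(F)F)CCC4)CC3)CC2)cn1`, is not yet measured. It differs from compound 3 by (1-(trifluoromethyl)cyclobutyl)methyl in place of (1-(trifluoromethyl)cyclopropyl)carbonyl on an amine nitrogen in a ring. This is a different kind of change: the carbonyl itself leaves, and the ring grows from three to four members. Among the compounds with values here, no measured step covers the loss of the carbonyl, so the three steps above bear on it only loosely, in that they show the response holding steady across several groups at this position. On that basis a step of a number 12 percentage points lower from compound 3 to compound 4 (beyond the scatter) is expected, that is, no change beyond the scatter, but with widened uncertainty. Compound 4 is estimated at 95%, in the range 70% to 115%.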

Compound 4, largest response reached (Emax), in percent of the reference or control that the assay uses: 96%
Compound 4: middle estimate off by 1 percentage points, on the low side; measured number inside the range.
By their numbers in this assay, from the lowest: compounds 2, 4, 1 and 3 (each within the scatter of the next, the first and the last beyond it).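

Compound 4 carries no carbonyl on the ring nitrogen, yet in this assay it still gives a large maximal response, so a high response at this position does not depend on having a carbonyl there. The comparison with the cyclopropyl amide shows a number 11 percentage points lower from compound 3 to compound 4 (beyond the scatter), a modest step, but two things change in it at once, the carbonyl leaving and the ring growing from three to four members, and the data cannot divide the step between them. The other comparisons, a number 1 percentage points higher from compound 2 to compound 4 (within the scatter) and a number 9 percentage points lower from compound 1 to compound 4 (within the scatter), stay within the scatter, so the group without a carbonyl cannot be told apart from the cyclopentyl amide or the fluorinated carbamate, and the response at this position remains fairly flat across all four groups.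

No measurement shown here explains the modest step. As far as these compounds go, a (1-(trifluoromethyl)cyclopropyl)methyl or a (1-(trifluoromethyl)cyclobutyl)carbonyl group on the same nitrogen would separate the loss of the carbonyl from the change in ring size, and the response of a compound with a free amine or a carboxylic acid in this group remains open.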